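Aryl swaps on the hydrazone carbon: expectation for compound 4

The source may report more compounds than this note shows. Statements on the series, on what has been measured and on what is new or still open speak of the compounds shown alone.

Measured so far:
compound 1 `CN(C)CCn1cnnc1-c1cc(Oc2ccc(NC(=O)N/N=C/c3c(Cl)cccc3Cl)cc2F)ccn1` gives 1410 nM in a functional assay on A549 cells (Homo sapiens) for cytotoxicity, read by MTT assay, with a stated time of 72 h; a higher number here means a weaker inhibitor, a lower number a stronger inhibitor
compound 2 `CN(C)CCn1cnnc1-c1cc(Oc2ccc(NC(=O)N/N=C/c3ccccc3O[N+](=O)[O-])cc2F)ccn1` gives 1200 nM
compound 3 `CN(C)CCn1cnnc1-c1cc(Oc2ccc(NC(=O)N/N=C/c3cccc(Br)c3)cc2F)ccn1` gives 970 nM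

Compound 3 sits at the low end of these three numbers, yet a 1.5-fold lower number from compound 1 to compound 3 (0.16 log units; within the scatter) and a 1.2-fold lower number from compound 2 to compound 3 (0.09 log units; within the scatter) both keep it within the scatter of its neighbours, so no order among the three is secure. Compound 4 `CN(C)CCn1cnnc1-c1cc(Oc2ccc(NC(=O)N/N=C/c3ccc(F)cc3Cl)cc2F)ccn1` differs from compound 3 by 2-chloro-4-fluorophenyl in place of 3-bromophenyl on a carbon with a double bond to nitrogen. The comparable aryl exchanges on that same carbon, a 1.2-fold lower number from compound 1 to compound 2 (0.07 log units; within the scatter) as well as the two steps just named, all stayed within the scatter, so from compound 3 to compound 4 no step beyond the scatter is expected, a 1.2-fold higher number from compound 3 to compound 4 (0.07 log units; within the scatter). Compound 4 is therefore estimated at about 1150 nM in this assay, with an expected range from 550 nM to 2400 nM.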

Compound 4, half-maximal inhibitory concentration: 1120 nM
The estimate for compound 4 lay 1.0-fold (0.01 log units) above the measured number; measured number inside the range.
By their numbers in this assay, from the lowest: compounds 3, 4, 2 and 1 (each within the scatter of the next).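

In this assay the 2-chloro-4-fluorophenyl group, the first here to carry fluorine on this aryl ring, adds three more steps within the scatter: a 1.2-fold higher number from compound 3 to compound 4 (0.06 log units; within the scatter) and a 1.1-fold lower number from compound 2 to compound 4 (0.03 log units; within the scatter) and a 1.3-fold lower number from compound 1 to compound 4 (0.10 log units; within the scatter). Four different aryl groups on this carbon therefore remain unresolved, and no order can be drawn among them. No measurement at hand bears on why these exchanges leave the number unresolved. Still open, on these data alone, is whether a morpholine or a carboxylic acid in place of the aryl group on this carbon would give a step beyond the scatter.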